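A few compounds are considered here, and "the series" means these few. Any claim that something is new, unique, unknown or untested is made for them only; others in the source may bear on it.

Among the measured compounds shown here, in a functional assay on HeLa cells (Homo sapiens) for cytotoxicity, read by sulforhodamine B assay, with a stated time of 72 h (a higher number here means a weaker inhibitor, a lower number a stronger inhibitor), compound 1 `COc1cc(NC(=O)/C=C/c2cccc(OC(F)(F)F)c2)cc(OC)c1OC` gives 4400 nM and stands lowest of the two numbers so far, with compound 2 `COc1ccccc1NC(=O)/C=C/c1cccc(OC(F)(F)F)c1` at 9800 nM and the gap between them beyond the usual scatter. Compound 3 `COc1cc(NC(=O)/C=C/c2cccc(O)c2)cc(OC)c1OC` carries the change hydrogen in place of trifluoromethyl on an oxygen on an aromatic ring in which hydrogen stands in place of trifluoromethyl on an oxygen on an aromatic ring, trifluoromethoxy to hydroxy. For the measured compounds named here, no measured pair in this assay covers this change, so a moderate rise in the number, meaning a weaker inhibitor, is expected, and the estimated 2.7-fold higher number from compound 1 to compound 3 (0.44 log units; beyond the scatter) remains a judgement only. Compound 3 is expected at 12000 nM with an estimated range from 4000 nM to 36000 nM in these notes.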

Compound 3, half-maximal inhibitory concentration: 18700 nM
Beside the measured number, compound 3's estimate is 1.6-fold (0.19 log units) below it, and the stated range covers the measured number.
By their numbers in this assay, from the lowest: compound 1; then compounds 2 and 3 (each within the scatter of the next).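

In this assay, among the compounds shown here, the first measured step at this place, trifluoromethoxy to hydroxy on an aromatic ring, reads a 4.3-fold higher number from compound 1 to compound 3 (0.63 log units; beyond the scatter) and so counts against compound 3. On the core of compound 1, the trifluoromethyl on this oxygen therefore cannot be replaced by hydrogen without a weaker inhibitor resulting. No measurement at hand accounts for the step.

As far as these compounds go, whether a methyl or a longer chain on this oxygen, or an amine in its place, would keep the number near that of compound 1 remains open. So does whether the same change would read alike on the core of compound 2.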